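This account rests on a few compounds, and the source may have more. Where it says the series, first, only, none or still open, it means among the compounds named here.

Measured so far in a functional assay on isolated protein for agonist activity at Free fatty acid receptor 1 (Homo sapiens), read by HTRF and inositol phosphate accumulation, with a stated time of 60 min; on this read-out higher numbers stand for an effect only at larger amounts of compound and lower numbers for an effect already at smaller amounts:
Compound 1 `O=C(O)CCCOc1ccc(-c2cccc(Oc3ccccc3)c2)cc1`: 6800 nM
Compound 2 `CCOc1ccc(F)c(-c2ccc(OCCCC(=O)O)cc2)c1`: 3190 nM
Compound 3 `O=C(O)CCCOc1ccc(-c2cc(Oc3ccccc3)ccc2F)cc1`: 3590 nM

On these three numbers compound 3 stands second highest. Its nearest neighbour is compound 2, and the step of a 1.1-fold higher number from compound 2 to compound 3 (0.05 log units; within the scatter) lies within the scatter. The furthest of the three is compound 1, and the step of a 1.9-fold lower number from compound 1 to compound 3 (0.28 log units; within the scatter) also lies within the scatter, so the three measured compounds are not separated from one another in this assay.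

Compound 4 `O=C(O)CCCOc1ccc(-c2cc(OC3CC3)ccc2F)cc1` differs from compound 3 in a single place: cyclopropyl in place of phenyl on an oxygen on an aromatic ring. Of the two measured steps, the one that bears directly on this change is the step from compound 2 to compound 3, which exchanged the group on the same oxygen and produced no shift beyond the scatter. The step from compound 1 to compound 3 touched another part of the molecule and speaks less to it. Among the compounds with values here, both steps are small, and nothing among the measured compounds points to a larger movement for a further exchange at this oxygen.

Compound 4 is therefore expected to give 3500 nM in this assay, with a range from 1500 nM to 8500 nM. The step of a 1.0-fold lower number from compound 3 to compound 4 (0.01 log units; within the scatter) this estimate implies is expected to stay within the scatter.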

Compound 4, half-maximal effective concentration: > 9950 nM
Compound 4 was reported as a limit; the forecaster's own chance of this, stated with the estimate: 5%; at least 2.8-fold (0.45 log units) between middle value and limit.
By their numbers in this assay, from the lowest: compounds 2, 3 and 1 (each within the scatter of the next, the first and the last beyond it). At a limit, above all of these: compound 4.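

In this assay compound 4 is reported only as a limit and not as a number: the limit of > 9950 nM in this assay, at which 1 of the 4 values shown sits.

Before this result, ethyl and phenyl on the oxygen could replace one another with no shift beyond the scatter, so the position looked open to exchange, but cyclopropyl gives an at least 2.7-fold higher number from compound 3 to compound 4 (0.44 log units; beyond the scatter) and an at least 3.1-fold higher number from compound 2 to compound 4 (0.49 log units; beyond the scatter). This is the first single exchange shown that moves the read-out beyond the scatter, and it moves it towards an effect only at larger amounts of compound, while an open chain and a six-membered aromatic ring on the same oxygen do not separate from each other.

Going by these compounds, how far compound 4 actually lies past its limit stays open, so the true size of both steps is unknown. Also open, on these data alone, is whether a longer chain such as propyl, or a larger non-aromatic ring such as cyclohexyl, on this oxygen would stay with compound 2 and compound 3 or go the way of compound 4.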